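The source may report more compounds than this note shows. Statements on the series, on what has been measured and on what is new or still open speak of the compounds shown alone.

This account follows the step from compound 3 to compound 4, measured in a functional assay on the whole organism with Rattus norvegicus as the target; a lower number here means that less compound is needed, a higher number that more compound is needed for the effect.

Compound 3, with the structure `N=c1sc2cc(OC(F)(F)F)ccc2n1CCS(N)(=O)=O`, gives 6 mg/kg in this assay, the lowest of the two numbers obtained so far. Compound 1, with the structure `CCCCCCc1ccc2nc(N)sc2c1`, gives 7 mg/kg, and the gap between compound 3 and compound 1 lies within the usual scatter, so the two cannot be told apart. Compound 2, with the structure `N=c1sc2cc(OC(F)(F)F)ccc2n1CC(=O)O`, gave only a limit rather than a number in this assay, recorded as > 10 mg/kg. Going by the values given here, the one measured step, an at least 1.6-fold lower number from compound 2 to compound 3 (0.22 log units; that floor lies within the scatter), is therefore known only as a floor, and the limit of > 10 mg/kg in this assay, at which 1 of the 3 values shown sits, marks where that floor sits.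

Compound 4 has the structure `CS(=O)(=O)CCn1c(=N)sc2cc(OC(F)(F)F)ccc21`. Its change from compound 3 is methyl in place of amino on a sulfonyl sulfur. Among the compounds with values here, no measured step touches the sulfonyl sulfur; the step of an at least 1.6-fold lower number from compound 2 to compound 3 (0.22 log units; that floor lies within the scatter) swapped the whole group on the chain carbon bound to the aromatic nitrogen, so it bears only loosely on this smaller change. With one hydrogen-bond donor removed and the rest of the molecule kept, the step of a 1.3-fold higher number from compound 3 to compound 4 (0.12 log units; within the scatter) is expected to stay near the scatter, leaning toward a slightly higher number. Compound 4 is estimated to give 8 mg/kg, within a range from 3 mg/kg to 20 mg/kg.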

Compound 4, dose for half-maximal effect: 1.8 mg/kg
The estimate for compound 4 lay 4.4-fold (0.65 log units) above the measured number; measured number below the stated range.
By their numbers in this assay, from the lowest: compound 4; then compounds 3 and 1 (each within the scatter of the next). At a limit, above all of these: compound 2.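

In this assay, the sulfonyl sulfur turns out to be a place where swapping a single heavy atom counts: methyl in place of amino gives a 3.3-fold lower number from compound 3 to compound 4 (0.52 log units; beyond the scatter), the first step shown here that lies beyond the scatter with real numbers at both ends. Measured against the carboxy compound, the (methylsulfonyl)methyl group gives an at least 5.5-fold lower number from compound 2 to compound 4 (0.74 log units; beyond the scatter), while the sulfamoylmethyl group reached only an at least 1.6-fold lower number from compound 2 to compound 3 (0.22 log units; that floor lies within the scatter), so the change away from carboxy now clears the scatter where the earlier step could not. Both of these steps are floors rather than sizes, since compound 2 carries a limit of the assay and not a number: the limit of > 10 mg/kg in this assay, at which 1 of the 4 values shown sits.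

This single pair of compounds cannot separate what losing the amino group contributes from what gaining the methyl group contributes, and no property of either group is measured here. On these data alone, it also remains open whether an ethyl or a dimethylamino group on the sulfonyl sulfur would follow methyl or amino in this assay, and whether a longer chain in place of the 2-(methylsulfonyl)ethyl group would keep the lower number.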